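This account rests on a few compounds, and the source may have more. Where it says the series, first, only, none or still open, it means among the compounds named here.

Measured so far in an ADME assay on MT4 cells (Homo sapiens) for cytotoxicity, read by MTT assay, with a stated time of 5 days; a lower number here means that less compound is tolerated, a higher number that more compound is tolerated:
- compound 1, `Cc1cccc(-c2cc(-c3ccccc3O)nc(N)n2)c1`: 13000 nM
- compound 2, `COc1cccc(-c2cc(-c3ccccc3O)nc(N)n2)c1`: only the limit > 78300 nM
- compound 3, `COc1ccc(-c2cc(-c3ccccc3O)nc(N)n2)cc1OC`: 7360 nM

Compound 1 holds the highest of the two plain numbers; compound 3 sits close enough that the gap lies within the scatter, so no order is claimed between them. Compound 2 is reported only as a limit, (the limit of > 78300 nM in this assay, at which 1 of the 3 values shown sits).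

The step to compound 4, `Nc1nc(-c2cccs2)cc(-c2ccccc2O)n1`, makes (thiophen-2-yl in place of 3-methylphenyl on an aromatic carbon). Both measured steps touch the same position: an at least 6.0-fold higher number from compound 1 to compound 2 (0.77 log units; beyond the scatter) and an at least 10-fold lower number from compound 2 to compound 3 (1.02 log units; beyond the scatter). Each alters substitution on a phenyl ring rather than exchanging the ring itself, and they pull in opposite directions, so they give no direction for a ring swap. The expected step is no change at the digits printed from compound 1 to compound 4 (within the scatter), nothing beyond the scatter. Compound 4 is therefore estimated at 13000 nM, between 4500 nM and 40000 nM.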

Compound 4, half-maximal cytotoxic concentration: 5300 nM
Estimate against measurement, compound 4: 2.5-fold (0.39 log units) above; low and high end bracket the measured number.
By their numbers in this assay, from the lowest: compounds 4, 3 and 1 (each within the scatter of the next, the first and the last beyond it). At a limit, above all of these: compound 2.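

Earlier steps at this position only altered substituents on a phenyl ring, whereas here the ring itself is exchanged. In this assay, thiophen-2-yl in place of 3-methylphenyl gives a 2.5-fold lower number from compound 1 to compound 4 (0.39 log units; beyond the scatter) and so less compound is tolerated, which shows that a ring exchange on this aromatic carbon can shift the number beyond the scatter. Nothing measured here accounts for this step.

Open: whether the direction holds for thiophen-3-yl or a pyridine ring. As far as these compounds go, also open: how a non-aromatic amine such as morpholine, or a carboxylic acid, would read at this position.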